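The source may hold more compounds than are shown below. What is called first, only, known or untested is meant among the compounds shown, and "the series" means these compounds.

Working notes on the series, values from a functional assay on HeLa cells (Homo sapiens) for cytotoxicity; on this read-out lower numbers stand for stronger inhibition of growth and higher numbers for weaker inhibition of growth:

- compound 1 `COc1ccc(NS(=O)(=O)c2c(F)c(F)c(F)c(Br)c2F)cc1`: 220 nM
- compound 2 `COc1ccc(NS(=O)(=O)c2ccc(F)c(F)c2F)cc1`: > 50000 nM (a limit of the assay, not a number)
- compound 3 `COc1ccc(NS(=O)(=O)c2c(F)c(Cl)c(F)c(Cl)c2F)cc1`: 96 nM
- compound 4 `COc1ccc(NS(=O)(=O)c2c(F)c(F)c(F)c(F)c2F)cc1`: not yet measured

Among the numerical values, compound 1 at 220 nM holds the higher one. Among the compounds with values here, the only other number belongs to compound 3 at 96 nM, and the gap between the two lies beyond the usual scatter. The remaining entry, for compound 2, is a limit.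

The step under study takes compound 1 to compound 4: fluoro in place of bromo on an aromatic carbon. Fluoro replaces bromo on an aromatic carbon, ortho to two fluoro groups and meta to a large group. Within the data shown here, no measured pair isolates a change of this kind, so the expectation rests on indirect comparison. Compound 4 shares with compound 1 at 220 nM and compound 3 at 96 nM a halogen on every free carbon of the ring, which compound 2 lacks. In this assay, a small move towards a lower number is expected, not clearly beyond the scatter. The expected step is a 1.7-fold lower number from compound 1 to compound 4 (0.23 log units; within the scatter). Compound 4 is estimated at 130 nM, with an expected range from 40 nM to 500 nM.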

Compound 4, concentration for 50% growth inhibition: 99 nM
Estimate against measurement, compound 4: 1.3-fold (0.12 log units) above; low and high end bracket the measured number.
By their numbers in this assay, from the lowest: compounds 3 and 4 (each within the scatter of the next); then compound 1. At a limit, above all of these: compound 2.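

In this assay, within the data shown here, the exchange of bromo for fluoro on this aromatic carbon gives a 2.2-fold lower number from compound 1 to compound 4 (0.35 log units; beyond the scatter), the only step confined to a single place, and the step is modest. Bromo is therefore not required at this position for growth inhibition at this level, since compound 4, with fluoro there, gives 99 nM. Nothing measured in the series bears on why the step runs in this direction.

From the compounds shown here alone, whether this carbon needs a halogen at all remains open, since a methoxy group, an amine or a carboxylic acid here would show how far the read-out depends on the group at this position, and a chlorine here, with the rest of compound 4 unchanged, would fill in the halogen comparison. Compound 2 gives only a limit of the assay, > 50000 nM, and it differs from compound 4 in more than one place, so the effect of hydrogen at this carbon alone also stays unresolved.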